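Amino in Place of Nitro on a Second Core

The source may hold more compounds than are shown below. What is called first, only, known or untested is meant among the compounds shown, and "the series" means these compounds.

Compound 1, `COc1ccc(/C=C\c2ccc3ccccc3c2)cc1[N+](=O)[O-]`, carries a nitro group on its core, while compound 2, `COc1ccc(/C=C\c2ccc3ccccc3c2)cc1N`, carries an amino group at the same place. In a functional assay on HT-29 cells (Homo sapiens) for inhibition (a lower number here means a stronger inhibitor, a higher number a weaker inhibitor), compound 1 gives 3280 nM, and compound 2 gives 1820 nM. The change between them is amino in place of nitro on an aromatic carbon, and it made a step of a 1.8-fold lower number from compound 1 to compound 2 (0.26 log units; within the scatter), so the two values cannot be told apart.

Compound 3, `COc1cc(/C=C/c2ccc3ccccc3c2)cc([N+](=O)[O-])c1OC`, is built on a different core; the difference between the two cores is not broken down here. In this assay compound 3 gives > 10000 nM, which is a limit of the assay and not a number: it sits at the limit of > 10000 nM in this assay, at which 1 of the 3 values shown sits. Compound 4, `COc1cc(/C=C/c2ccc3ccccc3c2)cc(N)c1OC`, has not yet been measured. It differs from compound 3 by amino in place of nitro on an aromatic carbon. Among the compounds with values here, the surroundings are not identical, since the amino group of compound 4 is also meta to a methoxy group, so this is the same kind of change as the one from compound 1 to compound 2, not the same one.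

Because the matching step was only a 1.8-fold lower number from compound 1 to compound 2 (0.26 log units; within the scatter), the expected step here is an at least 1.2-fold lower number from compound 3 to compound 4 (0.09 log units; that floor lies within the scatter). Compound 4 is therefore estimated at 8000 nM, between 3000 nM and 30000 nM, and there is a fair chance that this assay again reports only a limit for compound 4 rather than a number.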

Compound 4, half-maximal inhibitory concentration: 6000 nM
Beside the measured number, compound 4's estimate is 1.3-fold (0.12 log units) above it; the range from low to high includes it.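

On the second core, amino in place of nitro gave a step of an at least 1.6-fold lower number from compound 3 to compound 4 (0.22 log units; that floor lies within the scatter) in this assay, and the amino compound on this core reads as a measured number. As far as these compounds go, compound 3 stands at > 10000 nM, which is a limit of the assay and not a number, so the step is known only by its floor and its true size stays unknown. The two steps are compatible with this change behaving alike on both cores, but they do not prove that it does, nor do they establish that amino gives a lower number than nitro on either core: the same change on two cores in this assay, a 1.8-fold lower number (0.26 log units; within the scatter) from compound 1 to compound 2 and an at least 1.6-fold lower number (0.22 log units; that floor lies within the scatter) from compound 3 to compound 4; the limit leaves it open whether they differ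

Only nitro and amino appear at this place in the compounds shown, so it stays open how a hydroxyl group, a nitrile or an acetylated amine would read on either core. The separate contribution of each core also stays open, as the two cores differ in more than one place and no pair shown isolates a single difference between them.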